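This account rests on a few compounds, and the source may have more. Where it says the series, first, only, none or still open, it means among the compounds named here.

Measured so far:
compound 1, `CN1CCN(c2ccc(S(=O)(=O)Oc3cccc(Cl)c3)cc2)C1=O`, gives 2100 nM in a functional assay on HT-29 cells (Homo sapiens) for antiproliferative activity, read by sulforhodamine B assay, with a stated time of 48 h; on this read-out higher numbers stand for weaker inhibition and lower numbers for stronger inhibition.
compound 2, `CN1CCN(c2ccc(S(=O)(=O)Oc3cccc([N+](=O)[O-])c3)cc2)C1=O`, gives 26000 nM in this assay.
compound 3, `CCCN1CCN(c2ccc(S(=O)(=O)Oc3cccc(Cl)c3)cc2)C1=O`, gives 13000 nM in this assay.

Compound 4, `CCCN1CCN(c2ccc(S(=O)(=O)Oc3cccc([N+](=O)[O-])c3)cc2)C1=O`, has not been measured yet. Its core differs from that of compound 1 by ethyl in place of hydrogen on a saturated chain carbon bound to an amide-type nitrogen in a ring, a change that on its own gave a 6.2-fold higher number from compound 1 to compound 3 (0.79 log units; beyond the scatter). The change from compound 3 to compound 4 is nitro in place of chloro on an aromatic carbon. The same change, at the same place, has been made once before: from compound 1 to compound 2 it is nitro in place of chloro on an aromatic carbon, and it gave a 12-fold higher number from compound 1 to compound 2 (1.09 log units; beyond the scatter). Compound 3 stands near compound 2 already, so the step from compound 3 to compound 4 is expected to be a 7.7-fold higher number from compound 3 to compound 4 (0.89 log units; beyond the scatter) because the earlier change gave a 12-fold higher number from compound 1 to compound 2 (1.09 log units; beyond the scatter). For compound 4 a value of about 100000 nM is therefore estimated, plausibly between 35000 nM and 300000 nM.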

Compound 4, half-maximal inhibitory concentration: > 100000 nM
Compound 4 was reported as a limit; the forecaster's own chance of this, stated with the estimate: 25%; the middle value sits exactly at the limit.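

In this assay compound 4 gives > 100000 nM, which is a limit of the assay and not a number. Nitro in place of chloro gives an at least 7.6-fold higher number from compound 3 to compound 4 (0.88 log units; beyond the scatter), and ethyl in place of hydrogen on the chain gives an at least 3.8-fold higher number from compound 2 to compound 4 (0.58 log units; beyond the scatter). Each change therefore moves the number the same way on both cores, towards weaker inhibition, but the size of the effect on the second core remains unsettled: the same change on two cores in this assay, a 12-fold higher number (1.09 log units; beyond the scatter) from compound 1 to compound 2 and an at least 7.6-fold higher number (0.88 log units; beyond the scatter) from compound 3 to compound 4; the limit leaves it open whether they differ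

Going by these compounds, only chloro and nitro appear on the aromatic ring, so the effect of a fluoro group or an amine at that place remains open. On these data alone, the effect of a longer chain on the amide-type nitrogen also remains open.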